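The source may report more compounds than this note shows. Statements on the series, on what has been measured and on what is new or still open speak of the compounds shown alone.

Of the compounds shown here, three built on one shared core have been tested in a functional assay on PA-1 cells (Homo sapiens) for cytotoxicity, read by MTT assay, with a stated time of 48 h; a higher number here means a weaker inhibitor, a lower number a stronger inhibitor. Compound 1 `Cn1cc(/C=C2/C(=O)Nc3ccccc32)c2cc(Nc3nccc(-c4ccccc4)n3)ccc21` gives 17300 nM. Compound 2 `Cn1cc(/C=C2/C(=O)Nc3ccccc32)c2cc(Nc3nccc(-c4ccc(O)cc4)n3)ccc21` gives 9270 nM. Compound 3 `Cn1cc(/C=C2/C(=O)Nc3ccccc32)c2cc(Nc3nccc(-c4ccc(Cl)cc4)n3)ccc21` gives 2430 nM. Compound 2 therefore stands in the middle of the three numbers: it differs from compound 1 by a 1.9-fold lower number from compound 1 to compound 2 (0.27 log units; within the scatter), a gap that stays within the scatter, while the change from hydroxy to chloro gives a 3.8-fold lower number from compound 2 to compound 3 (0.58 log units; beyond the scatter), a gap beyond the scatter.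

Compound 4 `Cn1cc(/C=C2/C(=O)Nc3ccccc32)c2cc(Nc3nccc(-c4ccc(Cl)cc4Cl)n3)ccc21` is not yet measured. It differs from compound 2 by 2,4-dichlorophenyl in place of 4-hydroxyphenyl on an aromatic carbon. Within the data shown here, two measured steps bear on this change. The step of a 3.8-fold lower number from compound 2 to compound 3 (0.58 log units; beyond the scatter) shows what replacing hydroxy with chloro does, and the step of a 7.1-fold lower number from compound 1 to compound 3 (0.85 log units; beyond the scatter) shows what a single chloro does relative to hydrogen. Among the measured compounds shown here, the second chloro in compound 4 has no measured counterpart, so the expected size is less certain. A lower number is expected for compound 4 in this assay, by about a 5.2-fold lower number from compound 2 to compound 4 (0.71 log units; beyond the scatter), giving an estimate of 1800 nM with a range from 600 nM to 5500 nM.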

Compound 4, half-maximal inhibitory concentration: > 100000 nM
Compound 4 gave a limit, no number (the forecaster's own chance of this, stated with the estimate: 2%); at least 55-fold (1.74 log units) between middle value and limit.
By their numbers in this assay, from the lowest: compound 3; then compounds 2 and 1 (each within the scatter of the next). At a limit, above all of these: compound 4.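

In this assay, compound 4 gives a limit rather than a number, so the steps to it are minimum sizes. The earlier compounds shown here showed a single chloro on the phenyl ring giving lower numbers, but adding a second chloro reverses this, with an at least 41-fold higher number from compound 3 to compound 4 (1.61 log units; beyond the scatter) as the step. The 2,4-dichlorophenyl compound also sits on the weak side of both simpler rings, with an at least 5.7-fold higher number from compound 1 to compound 4 (0.76 log units; beyond the scatter) and an at least 10-fold higher number from compound 2 to compound 4 (1.03 log units; beyond the scatter) as the steps, so the effects of chloro at this position do not simply add up.

From the compounds shown here alone, it remains open whether this loss is specific to the second chloro or would follow any added group there, a question that a methyl or methoxy group in its place could address. Going by these compounds, the true value of compound 4 also remains unknown.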